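The source may report more compounds than this note shows. Statements on the series, on what has been measured and on what is new or still open speak of the compounds shown alone.

Measured so far in a functional assay on MNK45 cells (Homo sapiens) for inhibition, read by MTT assay, with a stated time of 48 h; on this read-out lower numbers stand for stronger inhibition and higher numbers for weaker inhibition:
Compound 1, `Cc1ccc(COc2ccc(C(=O)NC(=S)Nc3ccc(C)c(-c4nc5ccccc5[nH]4)c3)cc2)cc1`: 11300 nM
Compound 2, `Cc1ccc(NC(=S)NC(=O)c2ccc(OCc3ccccc3Cl)cc2)cc1-c1nc2ccccc2[nH]1`: 51400 nM

Among the compounds with values here, compound 2 stands highest of these two numbers in this assay; its only neighbour, compound 1, gives 11300 nM. Compound 3, `Cc1ccc(NC(=S)NC(=O)c2ccc(OCc3ccc(F)cc3)cc2)cc1-c1nc2ccccc2[nH]1`, carries 4-fluorophenyl in place of 2-chlorophenyl on a saturated chain carbon bound to an oxygen on an aromatic ring. Within the data shown here, one measured step bears on this change: a 4.5-fold higher number from compound 1 to compound 2 (0.66 log units; beyond the scatter), which brought in the 2-chlorophenyl that now leaves. Exchanging that 2-chlorophenyl for another substituted phenyl is therefore expected to return a lower number, of about the size of that earlier step, a 3.4-fold lower number from compound 2 to compound 3 (0.53 log units; beyond the scatter). Compound 3 is estimated at 15000 nM, with a range of 5000 nM to 45000 nM.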

Compound 3, half-maximal inhibitory concentration: 4220 nM
For compound 3 the middle estimate is 3.6-fold (0.55 log units) above the measured one; the whole stated range lies above it.
By their numbers in this assay, from the lowest: compound 3; then compound 1; then compound 2.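

In this assay, replacing 2-chlorophenyl with 4-fluorophenyl on a saturated chain carbon bound to an oxygen on an aromatic ring gives a 12-fold lower number from compound 2 to compound 3 (1.09 log units; beyond the scatter) here, a larger change than the earlier step had shown. The 4-fluorophenyl also outperforms the 4-methylphenyl of compound 1, with a 2.7-fold lower number from compound 1 to compound 3 (0.43 log units; beyond the scatter) in this comparison, so the gain does not depend on losing the 2-chlorophenyl alone. Nothing measured here accounts for these differences. The change alters both the halogen and its ring position, and a 4-chlorophenyl group would separate the two. On these data alone, how a cyclohexyl group would fare at this place also remains open.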